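From Methyl to Butyl in a Sulfonamide Pair

This account rests on a few compounds, and the source may have more. Where it says the series, first, only, none or still open, it means among the compounds named here.

Compound 1 `CCc1ccccc1NS(=O)(=O)c1ccc(N2CCNC2=O)cc1` gives 240 nM
Compound 2 `Cc1ccc(NS(=O)(=O)c2ccc(N3CCNC3=O)cc2)cc1` gives 480 nM

In a functional assay on HT-29 cells (Homo sapiens) for antiproliferative activity, read by sulforhodamine B assay, with a stated time of 48 h (on this read-out lower numbers stand for stronger inhibition and higher numbers for weaker inhibition), compound 2 stands at 480 nM, within the scatter of compound 1, so these two values cannot be put in order. Compound 3 `CCCCc1ccc(NS(=O)(=O)c2ccc(N3CCNC3=O)cc2)cc1` differs from compound 2 by propyl in place of hydrogen on a saturated chain carbon bound to an aromatic carbon, which can also be read as methyl to butyl: propyl in place of hydrogen on a saturated chain carbon bound to an aromatic carbon. Among the compounds with values here, only one measured step bears on this change: a 2.0-fold higher number from compound 1 to compound 2 (0.30 log units; within the scatter), with 4-methylphenyl in place of 2-ethylphenyl on a sulfonamide nitrogen. Within the data shown here, that is a different change, and no measured compound carries a butyl group, so the data give no firm direction. The step expected in this assay is therefore none beyond the scatter, an estimated 1.2-fold lower number from compound 2 to compound 3 (0.08 log units; within the scatter). For compound 3 the estimated value is 400 nM, with an expected range of 130 nM to 1200 nM.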

Compound 3, half-maximal inhibitory concentration: 610 nM
Compound 3: the middle estimate sits 1.5-fold (0.18 log units) below what was measured; the measured number falls inside the stated range.
By their numbers in this assay, from the lowest: compounds 1, 2 and 3 (each within the scatter of the next, the first and the last beyond it).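

In this assay, within the data shown here, the step from methyl to butyl at this position is the first measured change on a saturated chain carbon bound to an aromatic carbon, and it amounts to a 1.3-fold higher number from compound 2 to compound 3 (0.10 log units; within the scatter). Adding propyl in place of hydrogen there therefore leaves compound 3 indistinguishable from compound 2 on this read-out, so a chain of this length gives no measurable separation from methyl. No supporting evidence bears on why this is so.

The pair shows only these two chain lengths on the shared core, so it does not settle whether a longer chain, such as hexyl, would separate from butyl. As far as these compounds go, whether an amine or a carboxylic acid in place of the butyl group would shift the number beyond the scatter also remains open.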